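Removing the methoxy from the aryl ring of compound 1

A few compounds are considered here, and "the series" means these few. Any claim that something is new, unique, unknown or untested is made for them only; others in the source may bear on it.

Going by the values given here, compound 1, with the structure `COc1ccc(-c2ncnn2-c2cc(OC)c(OC)c(OC)c2)cc1`, is the only compound here with a numerical result: in a functional assay on Jurkat cells (Homo sapiens) for antiproliferative activity, read by MTT assay, with a stated time of 72 h (on this read-out lower numbers stand for stronger inhibition and higher numbers for weaker inhibition), compound 1 gives 50 nM. Compound 2, `COc1cc(-c2ncnn2-c2ccc(Cl)cc2)cc(OC)c1OC`, stands apart. In this assay compound 2 gives only > 10000 nM, which is a limit of the assay and not a number, as noted in the limit of > 10000 nM in this assay, at which 1 of the 2 values shown sits. Compound 3, `COc1cc(-n2ncnc2-c2ccccc2)cc(OC)c1OC`, has not yet been measured. It differs from compound 1 by hydrogen in place of methoxy on an aromatic carbon. Among the compounds with values here, no step between measured compounds is available to size this change directly, so the expectation rests on the two values shown. Since compound 2 reached only the limit in this assay, a loss well beyond the scatter is expected from compound 1 to compound 3, by a 40-fold higher number from compound 1 to compound 3 (1.60 log units; beyond the scatter). For compound 3 an estimated value of 2000 nM is expected, within 300 nM to 10000 nM.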

Compound 3, half-maximal inhibitory concentration: > 10000 nM
Compound 3 ended at the assay's limit; the forecaster's own chance of this, stated with the estimate: 30%; middle value at least 5.0-fold (0.69 log units) from the limit.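

Taking away the methoxy gives an at least 200-fold higher number from compound 1 to compound 3 (2.30 log units; beyond the scatter) in this assay, the first direct measure of this position: on the core of compound 1, hydrogen does not replace methoxy without a loss well beyond the scatter. Compound 3 gives > 10000 nM, which is a limit of the assay and not a number. The full size of the loss therefore cannot be read, and the step fixes only its smallest size: the limit of > 10000 nM in this assay, at which 2 of the 3 values shown sit.

The compounds shown leave open whether this position depends on methoxy itself, since it cannot be told whether hydroxy, ethoxy, an amine or a fluorine atom on this aromatic carbon would bring the number back towards that of compound 1. Nor do they show whether a longer chain, such as propoxy, would be tolerated there.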